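The compounds below may be only part of what the source reports. "The series", "measured", "known", "first", "only" and "open" are said of these compounds alone.

For the measured compounds named here, compound 3, `Nc1nc(N)c(-c2ccc(NCc3ccc([N+](=O)[O-])cc3)cc2)c(COCc2ccccc2)n1`, sits at 5.8 nM in a functional assay on CHOK cells for antagonist activity at growth hormone secretagogue receptor type 1 (Homo sapiens), read by calcium flux (on this read-out higher numbers stand for weaker inhibition and lower numbers for stronger inhibition), the lowest of the three numbers known. Going by the values given here, its nearest neighbour is compound 1, `CCc1nc(N)nc(N)c1-c1ccc(NCc2ccc([N+](=O)[O-])cc2)cc1`, which gives 23 nM; the step of a 4.0-fold lower number from compound 1 to compound 3 (0.60 log units; beyond the scatter) is the only single-point comparison available. Compound 2, `CCc1nc(N)nc(N)c1-c1ccc(NCc2cc(F)c(S(=O)(=O)C(F)(F)F)c(F)c2)cc1`, gives 690 nM, the highest of the three, and its values against compound 1 show only that a different substituted benzyl can raise the number considerably. Compound 4, `Nc1nc(N)c(-c2ccc(NCc3ccnc(Cl)c3)cc2)c(COCc2ccccc2)n1`, differs from compound 3 by 2-chloropyridin-4-yl in place of 4-nitrophenyl on a saturated chain carbon bound to a nitrogen on an aromatic ring. Among the compounds with values here, no measured step bears on this exchange directly, so the expectation rests on compound 3 alone. A modest rise is expected, a 2.6-fold higher number from compound 3 to compound 4 (0.41 log units; beyond the scatter), giving an estimated 15 nM for compound 4, within 4 nM to 60 nM.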

Compound 4, half-maximal inhibitory concentration: 3.6 nM
Estimate against measurement, compound 4: 4.2-fold (0.62 log units) above, and the stated range ends above it.
By their numbers in this assay, from the lowest: compounds 4 and 3 (each within the scatter of the next); then compound 1; then compound 2.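

In this assay, 2-chloropyridin-4-yl in place of 4-nitrophenyl gives a 1.6-fold lower number from compound 3 to compound 4 (0.21 log units; within the scatter), so the two groups cannot be told apart here. On a saturated chain carbon bound to a nitrogen on an aromatic ring, the nitro group is therefore not needed to keep the low number that compound 3 shows, and a ring with a hetero atom serves as well. Nothing at hand offers an explanation for this match. Still open, as far as these compounds go, is whether an unsubstituted pyridin-4-yl, or an amine or methoxy group in place of the chlorine, would hold the number. So is whether 2-chloropyridin-4-yl behaves alike with the ethyl group of compound 1 in place of the benzyloxymethyl group.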